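A few compounds are considered here, and "the series" means these few. Any claim that something is new, unique, unknown or untested is made for them only; others in the source may bear on it.

Measured compounds:
compound 1, `CCc1ccccc1NS(=O)(=O)c1ccc(NC(=O)NCCCCl)cc1`: > 200000 nM in a functional assay on HT-29 cells (Homo sapiens) for cytotoxicity, read by sulforhodamine B assay, with a stated time of 48 h; a higher number here means a weaker inhibitor, a lower number a stronger inhibitor
compound 2, `CCCc1ccccc1NS(=O)(=O)c1ccc(NC(=O)NCCCCl)cc1`: 26000 nM in this assay

Compound 1 stands at the limit of > 200000 nM in this assay, at which 1 of the 2 values shown sits; for compound 1 this assay gives no number, only a limit. Compound 2 carries a propyl in place of the ethyl on the aniline ring of the shared core, and the change reads an at least 7.6-fold lower number from compound 1 to compound 2 (0.88 log units; beyond the scatter); this step is the only one measured here.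

Compound 3, `CCNC(=O)Nc1ccc(S(=O)(=O)Nc2ccccc2CC)cc1`, keeps the ethyl group of compound 1 and alters the urea side instead: hydrogen in place of chloromethyl on a saturated chain carbon, two bonds along the chain from an amide-type nitrogen. Going by the values given here, none of the measured steps touches that end of the molecule, so the single step known, from compound 1 to compound 2, tells nothing about whether the shortening of the chloropropyl chain to ethyl moves the number. With compound 1 sitting at a limit, any expectation for compound 3 in this assay rests on that limit alone, and a further limit rather than a number is the likeliest outcome.

On that basis compound 3 is expected to give about 250000 nM, between 80000 nM and 800000 nM, in this assay, which would be a step that the limit leaves unreadable from compound 1 to compound 3 and is an estimate only.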

Compound 3, half-maximal inhibitory concentration: 86000 nM
Beside the measured number, compound 3's estimate is 2.9-fold (0.46 log units) above it; low and high end bracket the measured number.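

Going by these compounds alone, the urea end of the molecule, which no earlier step touched, also moves the number in this assay: replacing the 3-chloropropyl with ethyl gives an at least 2.3-fold lower number from compound 1 to compound 3 (0.36 log units; beyond the scatter). The change removes the chlorine and shortens the chain, and the shorter chain without chlorine still gives a readable number, so the chloromethyl is not needed for a measurable value on this core. For compound 1 the assay gives only a limit, so this step has a lower bound and no exact size: the limit of > 200000 nM in this assay, at which 1 of the 3 values shown sits.

Compound 2 and compound 3 differ in two places, so the compounds shown leave open how the propyl and the ethylamino change would act together on the shared core. As far as these compounds go, they also cannot separate the loss of chlorine from the shortening of the chain, and it remains open how the number would respond to a plain propyl chain, a longer chain, or an amine or a carboxylic acid at the end of the chain.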